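Swapping a Furan for a Fluoromethoxyphenyl in a Cytotoxicity Series

The compounds below may be only part of what the source reports. "The series", "measured", "known", "first", "only" and "open" are said of these compounds alone.

Compound 1 `CCOC(=O)CCCCCOc1cccc(CN(C(=O)c2ccc(-c3cccc(-c4ccccc4)c3)cc2)C(C)C)c1` and compound 2 `CCOC(=O)CCCCCOc1cccc(CN(C(=O)c2ccc(-c3ccco3)cc2)C(C)C)c1` share one core and differ only in the group on one aromatic carbon. In an ADME assay on HepG2 cells (Homo sapiens) for cytotoxicity, read by CellTiter-Glo and resazurin assay, with a stated time of 72 h (a lower number here means that less compound is needed, a higher number that more compound is needed for the effect), compound 1 gives > 26000 nM, which is a limit of the assay rather than a number. Compound 2 likewise gives > 26000 nM in this assay, again a limit. The step that the two limits leave unreadable from compound 1 to compound 2 therefore cannot be read, because of the limit of > 26000 nM in this assay, at which 2 of the 2 values shown sit. Among the measured compounds shown here, compound 2 thus stands at the limit, and the only other value shown sits there too.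

Compound 3 `CCOC(=O)CCCCCOc1cccc(CN(C(=O)c2ccc(-c3cc(F)cc(OC)c3)cc2)C(C)C)c1` carries 3-fluoro-5-methoxyphenyl in place of furan-2-yl on an aromatic carbon. For the measured compounds named here, the single measured step bears on this change only in that both of its ends are limits, so no direction and no size can be taken from it. The expected step that the limit leaves unreadable from compound 2 to compound 3 is therefore none beyond the scatter, with the value of compound 3 expected to remain a limit. The estimate for compound 3 is 30000 nM, within 15000 nM to 60000 nM.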

Compound 3, half-maximal effective concentration: > 26000 nM
Compound 3: no number, only a limit (the forecaster's own chance of this, stated with the estimate: 80%); the middle value does not contradict the limit.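

In this assay compound 3 gives > 26000 nM, again a limit and not a number. The steps from compound 1 and compound 2 to compound 3 therefore cannot be read. The compounds shown leave open whether the group on this aromatic carbon affects the value at all.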